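The compounds below may be only part of what the source reports. "The series", "measured", "known", "first", "only" and "open" are said of these compounds alone.

In a functional assay on MCF7 cells (Homo sapiens) for cytotoxicity, read by MTT assay, with a stated time of 2 days (a lower number here means that less compound is tolerated, a higher number that more compound is tolerated), compound 1, with the structure `CC(=O)c1cc(-c2ccc(F)cc2)cc2cc(-c3ccccc3)[nH]c12`, gives only a limit of the assay, > 100000 nM. Compound 2 `CC(=O)c1cc(-c2ccc(F)cc2)cc2cc(-c3ccc(F)cc3)[nH]c12` gives 87400 nM. The step between these two is an at least 1.1-fold lower number from compound 1 to compound 2 (0.05 log units; that floor lies within the scatter). Compound 3 `COc1ccc(-c2cc3cc(-c4ccc(F)cc4)cc(C(C)=O)c3[nH]2)cc1` also gives only a limit, > 100000 nM. The step from the first of these to compound 3 is a step that the two limits leave unreadable from compound 1 to compound 3, which follows from the limit of > 100000 nM in this assay, at which 2 of the 3 values shown sit. Compound 4 `CC(=O)c1cc(/C=C/c2ccccc2)cc2cc(-c3ccccc3)[nH]c12` differs from compound 1 by 2-phenylethenyl in place of 4-fluorophenyl on an aromatic carbon. Among the compounds with values here, both measured steps alter a different part of the shared core, so neither speaks directly to this change, and the one readable step stayed within the scatter. Compound 4 is therefore expected close to the limit, a step of a number no higher from compound 1 to compound 4 (the limit leaves the size open). The estimate for compound 4 is 100000 nM, between 30000 nM and 300000 nM.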

Compound 4, concentration lethal to 50% of the cells: > 100000 nM
Compound 4 gave a limit, no number; the forecaster's own chance of this, stated with the estimate: 60%; the middle value lies on the limit itself.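

Compound 4 gives > 100000 nM as a limit of the assay, not a number. The step from compound 1 to compound 4 therefore cannot be read, because both compounds stop at a limit: the limit of > 100000 nM in this assay, at which 3 of the 4 values shown sit. As far as these compounds go, whether 2-phenylethenyl in place of 4-fluorophenyl changes how much compound is tolerated stays open.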